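A few compounds are considered here, and "the series" means these few. Any claim that something is new, unique, unknown or untested is made for them only; others in the source may bear on it.

Compound 1 `COC(=O)C1=C(C)N=C(C)/C(=C(\O)OC)C1c1ccc(Cl)cc1` gives 8130 nM in a functional assay (muscle tissue) with Cavia porcellus as the target; on this read-out higher numbers stand for an effect only at larger amounts of compound and lower numbers for an effect already at smaller amounts. Compound 2 `COC(=O)C1=C(C)N=C(C)/C(=C(\O)OC)C1c1ccccc1Cl` gives 2.19 nM in this assay. Compound 3 `COC(=O)C1=C(C)N=C(C)/C(=C(\O)OC)C1c1ccccc1I` gives 46.8 nM in this assay.

Compound 3 stands second highest of the three numbers: its nearest neighbour is compound 2 (a 21-fold higher number from compound 2 to compound 3 (1.33 log units; beyond the scatter)) and its furthest is compound 1 (a 170-fold lower number from compound 1 to compound 3 (2.24 log units; beyond the scatter)). Compound 4 `COC(=O)C1=C(C)N=C(C)/C(=C(\O)OC)C1c1ccc(Cl)cc1Cl` differs from compound 3 by 2,4-dichlorophenyl in place of 2-iodophenyl on a saturated ring carbon. Among the compounds with values here, two measured steps bear on this. Exchanging 4-chlorophenyl for 2-chlorophenyl gave a 3700-fold lower number from compound 1 to compound 2 (3.57 log units; beyond the scatter), and exchanging it for 2-iodophenyl gave a 170-fold lower number from compound 1 to compound 3 (2.24 log units; beyond the scatter), while chloro against iodo gave a 21-fold higher number from compound 2 to compound 3 (1.33 log units; beyond the scatter). Within the data shown here, compound 4 keeps a 2-chloro and adds a 4-chloro; no measured step shows what a second chloro does. Compound 4 is therefore expected to give a lower number than compound 3, a 5.9-fold lower number from compound 3 to compound 4 (0.77 log units; beyond the scatter). Compound 4 is estimated at 8 nM, between 2 nM and 40 nM.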

Compound 4, half-maximal effective concentration: 640 nM
Compound 4: middle estimate off by 80-fold (1.90 log units), on the low side; measured number outside the range, above it.
By their numbers in this assay, from the lowest: compound 2; then compound 3; then compound 4; then compound 1.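

A second chloro on the phenyl ring moves the number in opposite directions depending on which chlorophenyl receives it: up when it joins the 2-chlorophenyl (a 290-fold higher number from compound 2 to compound 4 (2.47 log units; beyond the scatter)), but down when it joins the 4-chlorophenyl (a 13-fold lower number from compound 1 to compound 4 (1.10 log units; beyond the scatter)). The 2,4-dichlorophenyl also sits above the 2-iodophenyl (a 14-fold higher number from compound 3 to compound 4 (1.14 log units; beyond the scatter)), so among these four compounds the lone 2-chloro of compound 2 gives the lowest number. No measurement here accounts for this reversal.

Open, from the compounds shown here alone, is how a nitro or methoxy group on this phenyl ring would compare with chloro and iodo.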